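A few compounds are considered here, and "the series" means these few. Any claim that something is new, unique, unknown or untested is made for them only; others in the source may bear on it.

Compound 2 `CCCc1nc(-c2ccccc2)c(CNCCCN2CCN(c3cccc(C)c3)CC2)o1` gives 1190 nM in an assay on HEK293 cells for inhibition of Voltage-dependent T-type calcium channel subunit alpha-1G (Homo sapiens), read by patch clamp (a higher number here means a weaker inhibitor, a lower number a stronger inhibitor), and stands at the lower of the two numbers recorded, though its distance to compound 1 is within the scatter. Compound 1 `CCCc1nc(-c2ccccc2)c(CNCCCN2CCN(c3cccc(C)c3C)CC2)o1` gives 1780 nM; the step of a 1.5-fold lower number from compound 1 to compound 2 (0.17 log units; within the scatter) is within the scatter. Compound 3 `CCCc1nc(-c2ccccc2)c(CNCCCN2CCN(c3ccccc3C)CC2)o1` differs from compound 2 by 2-methylphenyl in place of 3-methylphenyl on an amine nitrogen in a ring. Within the data shown here, the only step that bears on this, a change of methyl count on the same aromatic ring, was within the scatter, so no step beyond the scatter is expected in this assay. Compound 3 is therefore expected at 1400 nM, range 600 nM to 3500 nM. The expected step is a 1.2-fold higher number from compound 2 to compound 3 (0.07 log units; within the scatter).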

Compound 3, half-maximal inhibitory concentration: 8750 nM
Compound 3: the middle estimate sits 6.3-fold (0.80 log units) below what was measured; the whole stated range lies below it.
By their numbers in this assay, from the lowest: compounds 2 and 1 (each within the scatter of the next); then compound 3.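

In this assay, the place of the single methyl on the phenyl at the ring amine nitrogen matters: 2-methylphenyl in place of 3-methylphenyl gives a step beyond the scatter (a 7.4-fold higher number from compound 2 to compound 3 (0.87 log units; beyond the scatter)). Replacing a methyl with hydrogen has two outcomes from the same parent: one step stays within the scatter (a 1.5-fold lower number from compound 1 to compound 2 (0.17 log units; within the scatter)), while the other does not (a 4.9-fold higher number from compound 1 to compound 3 (0.69 log units; beyond the scatter)). The outcome therefore depends on which methyl is replaced, and only compound 3, carrying 2-methylphenyl alone, stands apart.

Nothing at hand gives a cause for this. As far as these compounds go, whether unsubstituted phenyl or 2-methoxyphenyl at this nitrogen would fall near compound 2 or near compound 3 remains open.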